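This account rests on a few compounds, and the source may have more. Where it says the series, first, only, none or still open, it means among the compounds named here.

In a functional assay with Mus musculus as the target (a lower number here means a stronger inhibitor, a higher number a weaker inhibitor), compound 1 `CCNC1CCCc2onc(O)c21` gives 278000 nM. Compound 2 `C=CCNC1CCCc2onc(O)c21` is reported only as a limit, > 500000 nM. The series thus already reaches (the limit of > 500000 nM in this assay, at which 1 of the 2 values shown sits), so compound 2 has no exact position on the scale. Compound 3 `CC(=O)OCCNC1CCCc2onc(O)c21` carries acetoxymethyl in place of vinyl on a saturated chain carbon bound to an amine nitrogen. Going by the values given here, one measured step bears on this change, since it falls at the same place: an at least 1.7-fold higher number from compound 1 to compound 2 (0.25 log units; that floor lies within the scatter). That step gives only a floor, so it offers weak guidance on size and none on any ceiling. In this assay, no step beyond the scatter is therefore expected, and no direction is favoured. For compound 3, the estimated value is 500000 nM, with an expected range of 200000 nM to 1200000 nM. This estimate implies an expected a number no higher from compound 2 to compound 3 (the limit leaves the size open).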

Compound 3, half-maximal inhibitory concentration: > 500000 nM
Compound 3 was reported as a limit (the forecaster's own chance of this, stated with the estimate: 60%); the middle value lies on the limit itself.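

Compound 3 joins compound 2 as a limit in this assay, so a second group at this place, acetoxymethyl with its 5 heavy atoms and 2 hydrogen-bond acceptors, also yields no exact position on the scale. Acetoxy in place of hydrogen on a saturated chain carbon, two bonds along the chain from an amine nitrogen, gives an at least 1.7-fold higher number from compound 1 to compound 3 (0.25 log units; that floor lies within the scatter), and this floor alone does not establish a real loss. The step from vinyl to acetoxymethyl cannot be read, and so the two groups cannot be ranked: the limit of > 500000 nM in this assay, at which 2 of the 3 values shown sit.

As far as these compounds go, whether a plain propyl chain, a hydroxyl or a carboxylic acid at this place would give an exact value remains open. So does the question of whether any such group could bring the number below that of compound 1.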